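The compounds below may be only part of what the source reports. "The series", "measured", "known", "first", "only" and "open" are said of these compounds alone.

Compound 3 `CCC1(Cc2ccccc2)OS(=O)(=O)C=C1OCc1ccc(F)cc1` has been tested in an ADME assay on HEL cells (Homo sapiens) for cytotoxicity, with a stated time of 3 days (on this read-out higher numbers stand for lower toxicity in this test and lower numbers for higher toxicity in this test), and in that test compound 3 gives >= 50000 nM, which is a limit of the assay and not a number. Compound 1 `CCC1(Cc2ccccc2)OS(=O)(=O)C=C1OCc1ccc([N+](=O)[O-])cc1` in this assay gives >= 80000 nM, also a limit. Compound 2 `CCC1(Cc2ccccc2)OS(=O)(=O)C=C1OCC#N` in this assay gives > 400000 nM, again only a limit. Because every value sits at a limit (the limit of > 400000 nM in this assay, at which 1 of the 3 values shown sits, (the limit of >= 50000 nM in this assay, at which 1 of the 3 values shown sits), (the limit of >= 80000 nM in this assay, at which 1 of the 3 values shown sits)), none of the steps among the three can be read: a step that the two limits leave unreadable from compound 1 to compound 2, a step that the two limits leave unreadable from compound 1 to compound 3 and a step that the two limits leave unreadable from compound 2 to compound 3 are all of unknown size. Compound 4 `CCC1(Cc2ccccc2)OS(=O)(=O)C=C1OCCc1ccccc1` differs from compound 3 by benzyl in place of 4-fluorophenyl on a saturated chain carbon bound to an oxygen on an unsaturated carbon. The two steps at that same place, from compound 1 to compound 2 and from compound 2 to compound 3, bear on this change, but their sizes stay hidden behind the limits, so no measured size can be carried over. The expected step is therefore a step that the limit leaves unreadable from compound 3 to compound 4, none beyond the scatter. Compound 4 is estimated at 100000 nM, within 30000 nM to 400000 nM, and is expected most likely to come back as a limit as well.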

Compound 4, minimum cytotoxic concentration: >= 20000 nM
Compound 4: only a limit was reported (the forecaster's own chance of this, stated with the estimate: 85%); the middle value lies beyond the limit too.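

In this assay compound 4 gives >= 20000 nM, which is a limit of the assay and not a number. For the compounds shown here, no step linking compound 4 to compound 1, compound 2 or compound 3 can be read. The compounds shown leave open how large any change at this place is in this assay.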